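The source may hold more compounds than are shown below. What is called first, only, known or untested is meant among the compounds shown, and "the series" means these compounds.

Measured so far:
- Compound 1, `CCc1cc2ccccc2nc1-c1cc(-c2ccc(C)cc2)no1`. In a functional assay on COLO 205 cells (Homo sapiens) for inhibition, read by MTT assay, with a stated time of 24 h (on this read-out higher numbers stand for weaker inhibition and lower numbers for stronger inhibition), compound 1 gives only a limit of the assay, > 100000 nM.
- Compound 2, `CCCc1cc2ccccc2nc1-c1cc(-c2ccc(C)cc2)no1`. In this assay compound 2 likewise gives only a limit, > 100000 nM.
- Compound 3, `CCCCc1cc2ccccc2nc1-c1cc(-c2ccc(C(F)(F)F)cc2)no1`. In this assay compound 3 gives 11900 nM.

Compound 4, `CCCCCc1cc2ccccc2nc1-c1cc(-c2ccc(C(F)(F)F)cc2)no1`, has not yet been measured in this assay. It differs from compound 3 by methyl in place of hydrogen on a saturated chain carbon, four bonds along the chain from an aromatic carbon. The same kind of change has been made once before among these compounds, from compound 1 to compound 2, where it reads (methyl in place of hydrogen on a saturated chain carbon, two bonds along the chain from an aromatic carbon); the place differs, two bonds along the chain from an aromatic carbon in the earlier pair against four bonds in the new one. The size of that earlier step, a step that the two limits leave unreadable from compound 1 to compound 2, cannot be read because of the limit of > 100000 nM in this assay, at which 2 of the 3 values shown sit. The difference between the core of compound 1 and the core of compound 3 is not broken down here; compound 3 is the only compound shown with a number rather than a limit.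

The expectation for compound 4 rests on compound 3 at 11900 nM, since the earlier step gives no readable size to lean on; the step from compound 3 to compound 4 is estimated at a 1.3-fold lower number from compound 3 to compound 4 (0.12 log units; within the scatter), close to no change. Compound 4 is therefore expected to give about 9000 nM, most likely between 2500 nM and 35000 nM.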

Compound 4, half-maximal inhibitory concentration: 24500 nM
The estimate for compound 4 lay 2.7-fold (0.43 log units) below the measured number; the range from low to high includes it.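

In this assay, methyl in place of hydrogen on a saturated chain carbon, four bonds along the chain from an aromatic carbon, gives a 2.1-fold higher number from compound 3 to compound 4 (0.31 log units; beyond the scatter), a modest step towards weaker inhibition on the core of compound 3. The same kind of change on the core of compound 1, two bonds along the chain from an aromatic carbon, cannot be read, because compound 1 and compound 2 both give only a limit of the assay: the limit of > 100000 nM in this assay, at which 2 of the 4 values shown sit. This leaves one readable case of the change, at one place on one core, so the compounds shown cannot tell whether the step would carry over to the other core, in either size or direction.

On these data alone, a single step also does not make a trend, so it remains open whether a longer chain on the core of compound 3 would move the number further or leave it where it is. It is equally open how that core would respond if an amine or a carboxylic acid took the place of the chain, since every compound shown carries a plain saturated chain there.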